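This account rests on a few compounds, and the source may have more. Where it says the series, first, only, none or still open, it means among the compounds named here.

Measured in a functional assay on L1210 cells (Mus musculus) for inhibition, read by MTT assay, with a stated time of 72 h; on this read-out higher numbers stand for weaker inhibition and lower numbers for stronger inhibition:
- compound 1 `COc1cc(NC(C)CCCNC(=O)Nc2cccc(F)c2)c2ncccc2c1`: 19000 nM
- compound 2 `COc1cc(NC(C)CCCNC(=O)NNC(=O)Nc2ccc(F)cc2)c2ncccc2c1`: 104000 nM
- compound 3 `COc1cc(NC(C)CCCNC(=O)NNC(=O)Nc2ccc(Br)cc2)c2ncccc2c1`: 51000 nM

Compound 3 holds the middle of the three numbers in this assay, with a value of 51000 nM. The next compound, compound 4 `COc1cc(NC(C)CCCNC(=O)Nc2ccc(C(F)(F)F)cc2)c2ncccc2c1`, has not yet been measured. It is derived from compound 3 by a single change: 4-(trifluoromethyl)phenyl replaces ((4-bromophenyl)carbamoyl)amino on an amide-type nitrogen (4-(trifluoromethyl)phenyl in place of ((4-bromophenyl)carbamoyl)amino on an amide-type nitrogen). Compound 1 likewise has a phenyl ring bearing a substituent on that nitrogen, so the closest guide is a 2.7-fold higher number from compound 1 to compound 3 (0.43 log units; beyond the scatter), read in reverse. The companion step, a 5.5-fold higher number from compound 1 to compound 2 (0.74 log units; beyond the scatter), points the same way. Among the compounds with values here, the halogen swap, a 2.0-fold lower number from compound 2 to compound 3 (0.31 log units; beyond the scatter), shows that the substituent on the ring can also shift the number modestly, but no measured compound carries trifluoromethyl. A modest move towards stronger inhibition is therefore expected, and the estimated change is a 2.8-fold lower number from compound 3 to compound 4 (0.45 log units; beyond the scatter). For compound 4 the expected value is 18000 nM, with an estimated range of 7000 nM to 45000 nM.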

Compound 4, half-maximal inhibitory concentration: 7400 nM
Compound 4: middle estimate off by 2.4-fold (0.39 log units), on the high side, and the stated range covers the measured number.
By their numbers in this assay, from the lowest: compound 4; then compound 1; then compound 3; then compound 2.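

In this assay, within the data shown here, putting 4-(trifluoromethyl)phenyl on the amide-type nitrogen in place of the longer ((4-bromophenyl)carbamoyl)amino group gives a 6.9-fold lower number from compound 3 to compound 4 (0.84 log units; beyond the scatter), and the matching swap for the fluoro partner gives a 14-fold lower number from compound 2 to compound 4 (1.15 log units; beyond the scatter), the only large step in the set. The new result also shows that a phenyl ring directly on this nitrogen does not fix the number at one level, as the ring's substitution still matters: a 2.6-fold lower number from compound 1 to compound 4 (0.41 log units; beyond the scatter). Nothing measured here explains these steps.

The compounds shown leave open whether the trifluoromethyl group itself or its location on the ring drives the difference from 3-fluorophenyl. From the compounds shown here alone, it also remains open how a 4-bromophenyl or 4-nitrilophenyl group on the same nitrogen would compare with 4-(trifluoromethyl)phenyl.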